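Hydrazinyl thiadiazole series: maximal electroshock working notes

The compounds below may be only part of what the source reports. "The series", "measured", "known", "first", "only" and "open" are said of these compounds alone.

Measured compounds:
compound 1 `Cc1ccccc1-c1nnc(N(C)NC2CCCC2)s1` — 110 mg/kg
compound 2 `Cc1ccccc1-c1nnc(NN(C)C(C)C)s1` — 140 mg/kg

In a functional assay on the whole organism with Mus musculus as the target, in the maximal electroshock model, with a stated time of 1 h (on this read-out higher numbers stand for an effect only at larger amounts of compound and lower numbers for an effect already at smaller amounts), compound 1 gives 110 mg/kg. Compound 2 carries the highest of the two numbers seen so far, and in this assay compound 2 gives 140 mg/kg. Its nearest neighbour is compound 1, and the gap between the two lies within the scatter, so no order between compound 1 and compound 2 can be read from these figures.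

Compound 3 `Cc1ccccc1-c1nnc(N(C)N(C)C)s1` has not yet been measured in this assay. Relative to compound 2 it differs in one place: a group of 5 heavy atoms (3 carbon, 2 nitrogen; no ring) in place of a group of 6 heavy atoms (4 carbon, 2 nitrogen; no ring), on an aromatic carbon. Among the compounds with values here, no step between measured compounds is known for this kind of change, so no counted step can be quoted for it.

Within the data shown here, with only two measured values, both close together, the expectation is that the step in this assay from compound 2 to compound 3 stays within the scatter, a 1.1-fold higher number from compound 2 to compound 3 (0.03 log units; within the scatter), with no direction that can be defended from the data. Compound 3 is therefore expected to give about 150 mg/kg in this assay, with a range from 80 mg/kg to 300 mg/kg.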

Compound 3, dose for half-maximal effect: 25 mg/kg
Compound 3: middle estimate off by 6.0-fold (0.78 log units), on the high side; measured number below the stated range.
By their numbers in this assay, from the lowest: compound 3; then compounds 1 and 2 (each within the scatter of the next).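

In this assay, this position on the aromatic carbon of the five-membered ring proves sensitive to the group it carries, which the close values of the first two compounds did not reveal: the change to (dimethylamino)(methyl)amino gives a 5.6-fold lower number from compound 2 to compound 3 (0.75 log units; beyond the scatter) and is beyond the scatter. Replacing cyclopentylamino with dimethylamino on the nitrogen gives a 4.4-fold lower number from compound 1 to compound 3 (0.64 log units; beyond the scatter), also beyond the scatter, so two separate changes both arrive at the lowest number in the set, that of compound 3. Within the data shown here, the group entering in place of the one from compound 2 has one heavy atom fewer and no hydrogen-bond donor, against one in the group that leaves, but these counts change together and the step does not separate them, and no supporting measurement bears on this result.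

From the compounds shown here alone, it remains open whether the low number of compound 3 would hold with a diethylamino group or a pyrrolidine ring on the same nitrogen. Also open, going by these compounds, is how a hydrogen or an ethyl group in place of the methyl on the nitrogen attached to the ring would read in this model.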